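The source may hold more compounds than are shown below. What is called first, only, known or untested is meant among the compounds shown, and "the series" means these compounds.

Compound 1 `Cc1ccnc2nc(-c3cccc(Cl)c3)cc(O)c12`: 38.9 nM
Compound 2 `Cc1cc(C)c2c(O)cc(-c3cccc(F)c3)nc2n1`: 53.7 nM

In a functional assay on NCI-H460 cells (Homo sapiens) for antiproliferative activity (a lower number here means a stronger inhibitor of growth, a higher number a weaker inhibitor of growth), compound 2 stands level with compound 1, as their two values lie within the usual scatter of repeated measurements. Compound 3 `Cc1cc(C)c2c(O)cc(-c3cccc(Cl)c3)nc2n1` differs from compound 2 in one place: chloro in place of fluoro on an aromatic carbon, with chloro in place of fluoro on an aromatic carbon. Within the data shown here, no measured pair shows this swap alone. Compound 1 already carries a chloro group and gives 38.9 nM, so no shift beyond the scatter is expected in this assay. The expected 1.2-fold lower number from compound 2 to compound 3 (0.08 log units; within the scatter) is small. For compound 3 the estimated value is 45 nM, with an expected range of 20 nM to 100 nM.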

Compound 3, concentration for 50% growth inhibition: 224 nM
The estimate for compound 3 lay 5.0-fold (0.70 log units) below the measured number; the measured number lies above the stated range.
By their numbers in this assay, from the lowest: compounds 1 and 2 (each within the scatter of the next); then compound 3.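

In this assay the swap of fluoro for chloro on the six-membered aromatic ring of carbon only gives a 4.2-fold higher number from compound 2 to compound 3 (0.62 log units; beyond the scatter) and so is not a neutral exchange in this series. Methyl in place of hydrogen on an aromatic carbon of the core gives a 5.8-fold higher number from compound 1 to compound 3 (0.76 log units; beyond the scatter) and shows that chloro on the ring does not carry the same number into a core with the added methyl. Nothing measured here explains either step.

On these data alone, whether the fluoro compound would keep its number without the added methyl remains open. So does how a methoxy group or an amine would behave at this ring position.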